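Will a methoxy group change a nontoxic compound?

The compounds below may be only part of what the source reports. "The series", "measured", "known", "first", "only" and "open" are said of these compounds alone.

- Compound 1 `COc1ccc(C(=O)/C=C/C=C/c2ccccc2)cc1`: > 100000 nM
- Compound 2 `COc1ccc(/C=C/C=C/C(=O)c2ccc(OC)cc2)cc1`: "not determined" (no result reported)
- Compound 3 `CN(C)c1ccc(/C=C/C=C/C(=O)c2ccccc2)cc1`: > 100000 nM

In an ADME assay on RAW264.7 cells (Mus musculus) for cytotoxicity, read by MTT assay (on this read-out higher numbers stand for weaker inhibition and lower numbers for stronger inhibition), compound 3 gives > 100000 nM, which is a limit of the assay and not a number. Compound 3 thus stands at the limit of > 100000 nM in this assay, at which 2 of the 3 values shown sit. Compound 4 `COc1ccc(C(=O)/C=C/C=C/c2ccc(N(C)C)cc2)cc1` differs from it by methoxy in place of hydrogen on an aromatic carbon. Among the compounds with values here, no measured pair shows this change directly. Compound 1, which also carries a methoxy group, gives > 100000 nM, also a limit. Within the data shown here, with that limit as the only guide, the expected step of a number no higher from compound 3 to compound 4 (the limit leaves the size open) is none beyond the scatter. Compound 4 is estimated at 100000 nM, with an expected range from 30000 nM to 200000 nM.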

Compound 4, half-maximal inhibitory concentration: > 100000 nM
Compound 4 was reported as a limit (the forecaster's own chance of this, stated with the estimate: 70%); the middle value lies on the limit itself.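

Compound 1, compound 3 and compound 4 all end at a limit rather than a number, so no step between them can be read: the limit of > 100000 nM in this assay, at which 3 of the 4 values shown sit.

From the compounds shown here alone, whether methoxy in place of hydrogen changes the toxicity to these cells at all remains open.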